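The source may report more compounds than this note shows. Statements on the series, on what has been measured and on what is new or still open speak of the compounds shown alone.

The three measured compounds share one core, and compound 1 `CC(C)CCn1ccc(-c2ccc(OCC3CC3)c(Cl)c2)c(C#N)c1=O`, compound 2 `CC(C)CCn1ccc(-c2ccc(Oc3ccccn3)cc2)c(C#N)c1=O` and compound 3 `CCCCn1ccc(-c2ccc(Oc3ccnc(C)c3)cc2)c(C#N)c1=O` differ in what is attached through the oxygen on its outer aromatic ring and in the chain on the core. In a functional assay on CHO cells for positive allosteric modulation of metabotropic glutamate receptor 2 (Homo sapiens), read by scintillation counting and GTPgammaS binding, with a stated time of 30 min (on this read-out higher numbers stand for an effect only at larger amounts of compound and lower numbers for an effect already at smaller amounts), compound 1 gives 110 nM, compound 2 gives 646 nM and compound 3 gives 398 nM. Compound 2 thus has the highest number of the three, though compound 3 stands within the usual scatter of it, while the gap down to compound 1 lies beyond that scatter.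

Compound 4 `Cc1ccc(Oc2ccc(-c3ccn(CCC(C)C)c(=O)c3C#N)cc2)c(C)n1` has not yet been measured. It arises from compound 2 through a single change: 2,6-dimethylpyridin-3-yl in place of pyridin-2-yl on an oxygen on an aromatic ring. Among the compounds with values here, no pair of measured compounds differs in exactly this way, so the size of the step cannot be read off directly. What the numbers do show is that compound 3, which also carries a methyl-bearing pyridine on the oxygen along with a different chain on the core, gives a value within the scatter of compound 2. The step from compound 2 to compound 4 is therefore expected to be small, a 1.8-fold lower number from compound 2 to compound 4 (0.27 log units; within the scatter), with at most a slight lean toward a lower number. For compound 4 in this assay, the expected value is 350 nM, within a range of 120 nM to 1000 nM.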

Compound 4, half-maximal effective concentration: 100 nM
Compound 4: the middle estimate sits 3.5-fold (0.54 log units) above what was measured; the whole stated range lies above it.
By their numbers in this assay, from the lowest: compounds 4 and 1 (each within the scatter of the next); then compounds 3 and 2 (each within the scatter of the next).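

In this assay, putting 2,6-dimethylpyridin-3-yl in place of pyridin-2-yl on an oxygen on an aromatic ring gives a 6.5-fold lower number from compound 2 to compound 4 (0.81 log units; beyond the scatter). Within the data shown here, this is the first step here in which only one place changes, and it shows that the group on this oxygen can by itself move the number by more than the scatter, with the chain on the core held the same. Nothing in the data given explains why this change has so large an effect.

Among these compounds, the change brings in two methyl groups and also moves the point of attachment on the pyridine, so the single step cannot say which of these matters; plain pyridin-3-yl, or 6-methylpyridin-3-yl, on the same oxygen would be needed to pull them apart. Among the compounds shown here, it also remains open whether 2,6-dimethylpyridin-3-yl would give a step of the same size on a different chain on the core, such as a longer chain than the one shared by compound 2 and compound 4.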